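Trimethoxyphenyl series: dichlorophenyl replacing dimethoxyphenyl on the core

The compounds below may be only part of what the source reports. "The series", "measured", "known", "first", "only" and "open" are said of these compounds alone.

Three compounds of this series have numbers in a functional assay on PC-3 cells (Homo sapiens) for antiproliferative activity, read by MTT assay, tested at 5 uM; a lower number here means a weaker effect, a higher number a stronger effect of the compound at the concentration tested. Compound 1 `COc1ccc(C2OC(c3cc(OC)c(OC)c(OC)c3)=NN2C(C)=O)c(OC)c1` gives 92% there, the highest of the three. Compound 2 `COc1cc(C(=O)N/N=C/c2ccc(F)c(F)c2)cc(OC)c1OC` gives 43.7%, and compound 3 `COc1cc(C(=O)N/N=C/c2ccc(Cl)c([N+](=O)[O-])c2)cc(OC)c1OC` gives 42.3%; both lie well beyond the scatter below compound 1. Within the data shown here, compounds 2 and 3 share neither the core of compound 1 nor the group under study, so no single-point step between measured compounds is available.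

Compound 4 `COc1cc(C2=NN(C(C)=O)C(c3cc(Cl)cc(Cl)c3)O2)cc(OC)c1OC` keeps the core of compound 1 with one change: 3,5-dichlorophenyl in place of 2,4-dimethoxyphenyl on a saturated ring carbon. Among the measured compounds shown here, no measured pair shows this exchange, and the two weaker compounds carry halogen-bearing rings on a different core, which can only be noted. The expectation is a moderate decrease in this assay, as the step from compound 1 to compound 4 is estimated at a number 22 percentage points lower from compound 1 to compound 4 (beyond the scatter), a change larger than the scatter. Compound 4 is therefore expected to give about 70% in this assay, within a range from 40% to 92%.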

Compound 4, a percentage reported as inhibition, at one concentration (the size of the read-out at that concentration, not a potency): 93.9%
Compound 4: middle estimate off by 23.9 percentage points, on the low side, outside the stated range (above it).
By their numbers in this assay, from the lowest: compounds 3 and 2 (each within the scatter of the next); then compounds 1 and 4 (each within the scatter of the next).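

In this assay, the exchange of 2,4-dimethoxyphenyl for 3,5-dichlorophenyl on the saturated ring carbon of the shared core gives a number 1.9 percentage points higher from compound 1 to compound 4 (within the scatter). Among these compounds, this position therefore accepts a dichlorinated ring in place of a dimethoxylated one without a measurable change in this read-out, something the earlier compounds, which offered no single-point step, could not show. The read-out comes from one concentration and is not a potency, and no measurement available here offers an explanation for this result.

Going by these compounds, it remains open whether a carboxylic acid or an amine on the phenyl ring at this position would hold the read-out at the same level. The compounds shown also leave open whether a longer chain could replace the acetyl group on the shared core.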